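The source may report more compounds than this note shows. Statements on the series, on what has been measured and on what is new or still open speak of the compounds shown alone.

Working notes on the series. In a functional assay on MGC-803 cells (Homo sapiens) for inhibition, read by MTT assay, with a stated time of 72 h (a higher number here means a weaker inhibitor, a lower number a stronger inhibitor), compound 1 `C#CCSc1nc(Nc2ccc(Br)cc2)c2ccncc2n1` gives 26000 nM. Compound 2 `C#CCSc1nc(Nc2ccc(OC)cc2)c2ccncc2n1` gives > 80000 nM, which is a limit of the assay and not a number. Compound 2 therefore has no exact place on the scale, and its standing is given only by the limit of > 80000 nM in this assay, at which 1 of the 2 values shown sits. The next change leads to compound 3 `C#CCSc1nc(Nc2ccc(O)cc2)c2ccncc2n1` and reads (hydrogen in place of methyl on an oxygen on an aromatic ring), that is, methoxy to hydroxy. Among the measured compounds shown here, only one measured step bears on it, an at least 3.0-fold higher number from compound 1 to compound 2 (0.48 log units; beyond the scatter), which lies beyond the scatter. That step alters the same substituent but replaces bromo, so it does not measure the loss of this methyl. As far as these compounds go, its size is also open-ended, and it gives only a loose guide. In this assay a modest move towards a lower number is expected, though the result may again be only a limit. The expected step is an at least 1.3-fold lower number from compound 2 to compound 3 (0.12 log units; that floor lies within the scatter). Compound 3 is estimated at 60000 nM, with an expected range from 25000 nM to 130000 nM.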

Compound 3, half-maximal inhibitory concentration: > 80000 nM
Compound 3 gave a limit, no number (the forecaster's own chance of this, stated with the estimate: 45%); middle value at least 1.3-fold (0.12 log units) away from the limit.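

In this assay compound 3 gives > 80000 nM, which is a limit of the assay and not a number. The step from methoxy to hydroxy therefore cannot be read, since compound 2 and compound 3 both stand only as limits, and no gain or loss can be assigned to the methyl on the oxygen. What can be read is the comparison with bromo, with an at least 3.0-fold higher number from compound 1 to compound 3 (0.48 log units; beyond the scatter), which lies beyond the scatter and, alongside an at least 3.0-fold higher number from compound 1 to compound 2 (0.48 log units; beyond the scatter), shows that both replacements of bromo on this aromatic carbon by an oxygen-linked group leave the series at the same limit: the limit of > 80000 nM in this assay, at which 2 of the 3 values shown sit.

As far as these compounds go, compound 1 is the only one of the three with an exact value, so how far compound 2 and compound 3 lie from that limit, and whether they differ from each other at all, stays open. Also open, from the compounds shown here alone, is whether the exact value depends on bromo itself or would persist with chloro, a methyl or an amine on the same aromatic carbon.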